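This account rests on a few compounds, and the source may have more. Where it says the series, first, only, none or still open, it means among the compounds named here.

Working notes on the series. Compound 1 `COc1cc(OC)c2c(=O)cc(/C=C/c3ccncc3)oc2c1` carries a pyridin-4-yl group on the chain; in a functional assay on SKHep cells (Homo sapiens) for antiproliferative activity, read by MTT assay, with a stated time of 12 h (on this read-out higher numbers stand for weaker inhibition and lower numbers for stronger inhibition), compound 1 gives only a limit, > 40000 nM. Compound 2 `COc1cc(OC)c2c(=O)cc(/C=C/c3ccc(F)cc3)oc2c1` carries 4-fluorophenyl in its place and in this assay gives 29200 nM, the only number shown so far; the step of an at least 1.3-fold lower number from compound 1 to compound 2 (0.13 log units; that floor lies within the scatter) rests on (the limit of > 40000 nM in this assay, at which 1 of the 2 values shown sits). Compound 3 `COc1cc(OC)c2c(=O)cc(/C=C/c3ccc(Br)cc3)oc2c1` is not yet measured; it differs from compound 2 by bromo in place of fluoro on an aromatic carbon. Among the compounds with values here, no measured step touches this exchange, so the expectation is anchored only on compound 2 at 29200 nM. The step of a 1.3-fold lower number from compound 2 to compound 3 (0.12 log units; within the scatter) is the estimate, within the scatter. For compound 3 in this assay the expected value is 22000 nM, between 9000 nM and 45000 nM.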

Compound 3, half-maximal inhibitory concentration: > 40000 nM
Compound 3: only a limit was reported; the forecaster's own chance of this, stated with the estimate: 25%; middle value at least 1.8-fold (0.25 log units) away from the limit.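

Bromo in place of fluoro gives an at least 1.3-fold higher number from compound 2 to compound 3 (0.13 log units; that floor lies within the scatter) in this assay, so the size of this exchange stays unread. Compound 3 gives only a limit, and such limits now make up most of the series: the limit of > 40000 nM in this assay, at which 2 of the 3 values shown sit. The step between compound 1 and compound 3 cannot be read, as both values are limits. On these data alone, whether an amine or a carboxylic acid in place of the fluoro would give a measurable number remains open. As far as these compounds go, the true value of compound 3 also remains open.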